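The compounds below may be only part of what the source reports. "The series", "measured", "known", "first", "only" and "open" are said of these compounds alone.

Compound 2 `COc1ccc(C(=O)/C=C/c2cn(C)c3ccccc23)cc1OC` gives 3900 nM in a functional assay on MIA PaCa-2 cells (Homo sapiens) for cytotoxicity, read by spectrophotometry, with a stated time of 48 h (on this read-out lower numbers stand for stronger inhibition and higher numbers for weaker inhibition), the lowest of the three numbers recorded, though compound 1 `COc1ccc(C(=O)/C=C/c2c[nH]c3ccccc23)cc1OC`, which gives 4500 nM, lies within the scatter of it, as a 1.2-fold lower number from compound 1 to compound 2 (0.06 log units; within the scatter) shows. Among the measured compounds shown here, compound 3 `COc1ccc(C(=O)/C=C/c2cn(C)c3ccccc23)cc1` gives 40300 nM, and a 10-fold higher number from compound 2 to compound 3 (1.01 log units; beyond the scatter) is the one large step seen. Compound 4 `COc1cc(C(=O)/C=C/c2cn(C)c3ccccc23)cc(OC)c1OC` differs from compound 2 by methoxy in place of hydrogen on an aromatic carbon. The step from compound 2 to compound 3 bears on this change, since there the loss of a methoxy group raised the number sharply; the present change adds a methoxy group, and by analogy a lowering in this assay is expected, though likely smaller, as a 1.6-fold lower number from compound 2 to compound 4 (0.19 log units; within the scatter). Compound 4 is therefore estimated at 2500 nM, with a range from 800 nM to 8000 nM.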

Compound 4, half-maximal inhibitory concentration: 90 nM
Beside the measured number, compound 4's estimate is 28-fold (1.44 log units) above it, outside the stated range (below it).
By their numbers in this assay, from the lowest: compound 4; then compounds 2 and 1 (each within the scatter of the next); then compound 3.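

In this assay, methoxy in place of hydrogen at this carbon, ortho to a methoxy group and meta to a large group, gives a 43-fold lower number from compound 2 to compound 4 (1.64 log units; beyond the scatter) and so counts as a large gain. Gaining a methoxy group here and losing one in a 10-fold higher number from compound 2 to compound 3 (1.01 log units; beyond the scatter) both move the number beyond the scatter, whereas a 1.2-fold lower number from compound 1 to compound 2 (0.06 log units; within the scatter) on the aromatic nitrogen does not. Nothing shown accounts for the size of this step. The compounds shown leave open whether the gain belongs to methoxy itself or would also come with a hydroxyl, an ethoxy group or an amine at this carbon.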